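A few compounds are considered here, and "the series" means these few. Any claim that something is new, unique, unknown or untested is made for them only; others in the source may bear on it.

Compound 1, `O=C(O)CCc1ccc(OCC2COc3ccc(Cl)cc3O2)cc1F`, is measured in a functional assay on HEK293 cells for agonist activity at Free fatty acid receptor 1 (Homo sapiens), read by fluorescence and calcium flux, with a stated time of 10 min (on this read-out higher numbers stand for larger maximal responses and lower numbers for smaller maximal responses), where compound 1 reaches 50%. Compound 2, `CCOC(CC(=O)O)c1ccc(OCC2COc3ccc(Cl)cc3O2)cc1`, is the second compound assessed in this assay, and compound 2 gives 46%. Among the compounds with values here, on these two numbers compound 2 stands beside compound 1, its only neighbour, and the two values lie within the scatter of each other, so nothing separates them. Within the data shown here, no step between measured compounds is available to guide the next move.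

Compound 3, `O=C(O)CC(c1ccc(F)cc1)c1ccc(OCC2COc3ccc(Cl)cc3O2)cc1`, departs from compound 2 by one change: 4-fluorophenyl in place of ethoxy on a saturated chain carbon bound to an aromatic carbon and a saturated chain carbon. Among the measured compounds shown here, with no measured step to lean on, the step from compound 2 to compound 3 in this assay is expected to be small, upward at most, and quite possibly not beyond the scatter, which an expected step of a number 9 percentage points higher from compound 2 to compound 3 (within the scatter) reflects. Compound 3 is therefore estimated to reach 55%, within a range of 35% to 80%.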

Compound 3, largest response reached (Emax), in percent of the reference or control that the assay uses: 83%
Estimate against measurement, compound 3: 28 percentage points below, outside the stated range (above it).
By their numbers in this assay, from the lowest: compounds 2 and 1 (each within the scatter of the next); then compound 3.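

In this assay the saturated chain carbon bound to an aromatic carbon and a saturated chain carbon proves to be a place where the maximal response can move, which compounds 1 and 2, lying within the scatter of each other, could not show. Putting 4-fluorophenyl in place of ethoxy there gives a number 37 percentage points higher from compound 2 to compound 3 (beyond the scatter) and so swaps a ringless group holding a hydrogen-bond acceptor for a larger six-membered aromatic ring without one. No measurement offered here accounts for the gain.

The compounds shown leave open whether the step comes from the aromatic ring or from its fluorine, which a plain phenyl at the same carbon would test. They also leave open whether a saturated ring such as cyclohexyl would serve there equally well.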